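From 4-methoxyphenyl to 3,4-difluorophenyl on the shared core

The compounds below may be only part of what the source reports. "The series", "measured", "known", "first", "only" and "open" are said of these compounds alone.

Compound 1 `O=C(C[C@]1(O)CC[C@@H](Cc2ccc(F)cc2)CC1)Nc1ccc2[nH]c(=O)oc2c1` and compound 2 `COc1ccc(C[C@H]2CC[C@](O)(CC(=O)Nc3ccc4[nH]c(=O)oc4c3)CC2)cc1` differ in one place on the shared core. In an ADME assay on the whole organism (strain Sprague-Dawley) for pharmacokinetics, with Rattus norvegicus as the target, using cassette dosing (a lower number here means slower removal, a higher number faster removal of the compound), compound 1 gives 36.8 mL/min/kg and compound 2 gives 45.9 mL/min/kg. For the measured compounds named here, compound 2 has the larger of only two numbers, but the pair lies within the usual scatter, so it does not stand apart from compound 1.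

Compound 3 `O=C(C[C@]1(O)CC[C@@H](Cc2ccc(F)c(F)c2)CC1)Nc1ccc2[nH]c(=O)oc2c1` follows from compound 2 by 3,4-difluorophenyl in place of 4-methoxyphenyl on a saturated chain carbon bound to a saturated ring carbon. Going by the values given here, the one measured step that bears on this change is methoxy in place of fluoro on an aromatic carbon, a 1.2-fold higher number from compound 1 to compound 2 (0.10 log units; within the scatter), and it stays within the scatter. Among the compounds with values here, compound 3 runs that exchange in reverse and adds one more fluorine, for which no measured step exists. No shift beyond the scatter is therefore expected in this assay. The expected change is a 1.2-fold lower number from compound 2 to compound 3 (0.08 log units; within the scatter), which is no real move in either direction. For compound 3 the estimated value is 38 mL/min/kg, with an expected range from 20 mL/min/kg to 68 mL/min/kg.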

Compound 3, clearance: 35.7 mL/min/kg
For compound 3 the middle estimate is 1.1-fold (0.03 log units) above the measured one; low and high end bracket the measured number.
By their numbers in this assay, from the lowest: compounds 3, 1 and 2 (each within the scatter of the next).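

In this assay, the exchange of 4-methoxyphenyl for 3,4-difluorophenyl on a saturated chain carbon bound to a saturated ring carbon gives a 1.3-fold lower number from compound 2 to compound 3 (0.11 log units; within the scatter), so a change of the whole aryl group at this place, and not only of the methoxy and fluoro exchange read earlier, leaves the clearance within the scatter. The step of fluoro in place of hydrogen on an aromatic carbon, which the earlier compounds could not show, gives a 1.0-fold lower number from compound 1 to compound 3 (0.01 log units; within the scatter) and is the smallest of the three steps among these compounds, so this added fluoro brings no readable change in this assay. All three compounds thus stay within the scatter of one another at this position, and nothing given here accounts for that result.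

What stays open is whether any group at this place can move the clearance beyond the scatter, since the set shown holds no amine or carboxylic acid on the aromatic ring and no longer chain in place of the benzyl group. It also leaves open whether the flat reading holds with other changes on the shared core.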